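A Further Methoxy on Compound 1

The compounds below may be only part of what the source reports. "The series", "measured", "known", "first", "only" and "open" are said of these compounds alone.

In a functional assay on A549 cells (Homo sapiens) for cytotoxicity, read by WST assay, with a stated time of 48 h (a higher number here means a weaker inhibitor, a lower number a stronger inhibitor), compound 1 (`COc1ccc2[nH]cc(/C=C(\C#N)C(=O)c3c[nH]c4ccccc34)c2c1`) gives 13700 nM in this series. Compound 2 (`COc1ccc2[nH]cc(/C=C(\C#N)C(=O)c3c[nH]c4ccc(OC)cc34)c2c1`) gives 24500 nM and compound 3 (`N#C/C(=C\c1c[nH]c2ccccc12)C(=O)c1c[nH]c2ccccc12`) gives 22000 nM in the same test. Compound 1 therefore stands level with both neighbours, since its steps to each lie within the scatter.

Compound 4 (`COc1ccc2c(C(=O)/C(C#N)=C/c3c[nH]c4ccc(OC)cc34)c[nH]c2c1`) differs from compound 1 by methoxy in place of hydrogen on an aromatic carbon.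

Within the data shown here, two measured steps bear on this change. The same kind of swap elsewhere gave a 1.8-fold higher number from compound 1 to compound 2 (0.25 log units; within the scatter), and removing the methoxy of compound 1 gave a 1.6-fold higher number from compound 1 to compound 3 (0.21 log units; within the scatter). Among the measured compounds shown here, both stay within the scatter, although no measured compound carries a methoxy at the new place. On that evidence, no step beyond the scatter is expected in this assay, and the estimated step is a 1.4-fold higher number from compound 1 to compound 4 (0.14 log units; within the scatter).

For compound 4 the estimated value is 19000 nM, with an expected range from 10000 nM to 38000 nM.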

Compound 4, half-maximal inhibitory concentration: 5500 nM
The estimate for compound 4 lay 3.5-fold (0.54 log units) above the measured number, and the stated range ends above it.
By their numbers in this assay, from the lowest: compound 4; then compounds 1, 3 and 2 (each within the scatter of the next).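

In this assay methoxy in place of hydrogen at this position gives a 2.5-fold lower number from compound 1 to compound 4 (0.40 log units; beyond the scatter) and is the only step shown that lies beyond the scatter, while the same swap at another place gives a 1.8-fold higher number from compound 1 to compound 2 (0.25 log units; within the scatter) and stays within it. Among these compounds, then, the outcome of adding a methoxy depends on where it sits on the shared core, and here, meta to a fused ring and para to a fused ring, it lowers the number modestly. No measurement shown accounts for this step.

The compounds shown leave open whether the lower number belongs to methoxy itself or would also follow from a hydroxy, an amine or a fluorine atom at this position. They also leave open whether the step depends on the methoxy already present in compound 1.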